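The source may hold more compounds than are shown below. What is called first, only, known or untested is meant among the compounds shown, and "the series" means these compounds.

Compound 1 (`CCN1CCc2c(sc(NC(=O)Nc3cccc(Cl)c3Cl)c2C(N)=O)C1`) gives 17400 nM
Compound 2 (`CCN1CCc2c(sc(NC=O)c2C(N)=O)C1`) has the limit > 25000 nM
Compound 3 (`CCN1CCc2c(sc(NC(=O)Nc3cccc(C#N)c3)c2C(N)=O)C1`) gives 10300 nM

In a functional assay (strain AB) with Danio rerio as the target, read by microscopy, with a stated time of 1 h (on this read-out lower numbers stand for an effect already at smaller amounts and higher numbers for an effect only at larger amounts of compound), compound 3 sits within the scatter of compound 1, and the only other result, that of compound 2, is a limit and not a number. Compound 4 (`CCN1CCc2c(sc(NC(=O)Nc3ccc(Br)cc3)c2C(N)=O)C1`) carries 4-bromophenyl in place of 3-cyanophenyl on an amide-type nitrogen. For the measured compounds named here, the one measured step at that nitrogen (a 1.7-fold lower number from compound 1 to compound 3 (0.23 log units; within the scatter)) also exchanged one substituted phenyl for another, and it stands alone as a guide. On that single step, no change beyond the scatter is expected in this assay here. The estimated step is small (a 1.3-fold higher number from compound 3 to compound 4 (0.10 log units; within the scatter)). A result at the limit remains possible (the limit of > 25000 nM in this assay, at which 1 of the 3 values shown sits). Compound 4 is expected at 13000 nM with an estimated range from 6000 nM to 25000 nM as the likely span.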

Compound 4, half-maximal effective concentration: 3130 nM
Compound 4: the middle estimate sits 4.2-fold (0.62 log units) above what was measured; measured number outside the range, below it.
By their numbers in this assay, from the lowest: compound 4; then compounds 3 and 1 (each within the scatter of the next). At a limit, above all of these: compound 2.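

In this assay, the choice of substituted phenyl on the amide-type nitrogen now moves the number beyond the scatter, with a 3.3-fold lower number from compound 3 to compound 4 (0.52 log units; beyond the scatter) and a 5.6-fold lower number from compound 1 to compound 4 (0.75 log units; beyond the scatter). Compound 2 has a limit and not a number: the limit of > 25000 nM in this assay, at which 1 of the 4 values shown sits. Read against that limit, the step is an at least 7.9-fold lower number from compound 2 to compound 4 (0.90 log units; beyond the scatter).

The group and its place on the phenyl ring change together here, and the compounds shown cannot tell these two changes apart. Also open, on these data alone, is how 4-chlorophenyl, 4-methoxyphenyl or benzyl would fare on this nitrogen.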